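The source may hold more compounds than are shown below. What is called first, only, known or untested is meant among the compounds shown, and "the series" means these compounds.

In a functional assay on MDA-MB-436 cells (Homo sapiens) for antiproliferative activity, read by MTT assay, with a stated time of 48 h (on this read-out lower numbers stand for stronger inhibition and higher numbers for weaker inhibition), compound 1 (`C=CS(=O)(=O)N1CCN(c2ncnc3sc(-c4ccc(N5CCN(C)CC5)cc4)cc23)CC1`) gives 8760 nM, compound 2 (`CN1CCN(c2ccc(-c3cc4c(N5CCN(S(=O)(=O)N6CCCCC6)CC5)ncnc4s3)cc2)CC1`) gives 7570 nM and compound 3 (`CN1CCN(c2ccc(-c3cc4c(N5CCN(C(=O)Nc6ccc(C#N)cc6)CC5)ncnc4s3)cc2)CC1`) gives 5010 nM. Compound 3 thus stands within the scatter of both others, as shown by a 1.7-fold lower number from compound 1 to compound 3 (0.24 log units; within the scatter) and a 1.5-fold lower number from compound 2 to compound 3 (0.18 log units; within the scatter). The remaining step, a 1.2-fold lower number from compound 1 to compound 2 (0.06 log units; within the scatter), is also within the scatter. Compound 4 (`CC(C)c1cccc(C(C)C)c1NC(=O)N1CCN(c2ncnc3sc(-c4ccc(N5CCN(C)CC5)cc4)cc23)CC1`) differs from compound 3 by 2,6-diisopropylphenyl in place of 4-cyanophenyl on an amide-type nitrogen, with 2,6-diisopropylphenyl in place of 4-cyanophenyl on an amide-type nitrogen. Within the data shown here, no measured step changes this group alone, so the three changes on the amine nitrogen in a ring are the nearest evidence. No step beyond the scatter is therefore expected in this assay. The expected step is a 1.0-fold lower number from compound 3 to compound 4 (0.00 log units; within the scatter). Compound 4 is estimated at 5000 nM, with an expected range of 2000 nM to 12000 nM.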

Compound 4, half-maximal inhibitory concentration: 11300 nM
Beside the measured number, compound 4's estimate is 2.3-fold (0.35 log units) below it, within the range that was stated.
By their numbers in this assay, from the lowest: compounds 3, 2, 1 and 4 (each within the scatter of the next, the first and the last beyond it).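

In this assay, replacing 4-cyanophenyl with 2,6-diisopropylphenyl on an amide-type nitrogen gives a 2.3-fold higher number from compound 3 to compound 4 (0.35 log units; beyond the scatter) and is the only step among these compounds that lies beyond the scatter, though it is modest. The earlier changes on the amine nitrogen in a ring had all stayed within the scatter, so this shows that the aryl group on the amide-type nitrogen can shift the number. Nothing available bears on the reason for this shift. The compounds shown do not separate the loss of 4-cyanophenyl from the entry of 2,6-diisopropylphenyl. Going by these compounds, it also remains open where an unsubstituted phenyl or a 4-methoxyphenyl on this nitrogen would fall.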